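This account rests on a few compounds, and the source may have more. Where it says the series, first, only, none or still open, it means among the compounds named here.

Measured so far in a functional assay on HepG2 cells (Homo sapiens) for antiproliferative activity, read by MTT assay, with a stated time of 72 h; on this read-out lower numbers stand for stronger inhibition and higher numbers for weaker inhibition:
- Compound 1 `COc1cc2c(Nc3ccc(C#N)cc3)ncnc2cc1OCCCN1CCCCC1`: 20700 nM
- Compound 2 `COc1cc2c(Nc3ccc(C#N)cc3)ncnc2cc1OCCCN1CCc2ccccc2C1`: > 100000 nM, a limit and not a number

Compound 2 stands only at a limit, as the limit of > 100000 nM in this assay, at which 1 of the 2 values shown sits, shows. Compound 3 `COc1cc2c(Nc3ccc(C#N)cc3)ncnc2cc1OCCCN1CCN(C)CC1` differs from it by 4-methylpiperazin-1-yl in place of 1,2,3,4-tetrahydroisoquinolin-2-yl on a saturated chain carbon, three bonds along the chain from an oxygen on an aromatic ring. Among the compounds with values here, one measured step bears on this, an at least 4.8-fold higher number from compound 1 to compound 2 (0.68 log units; beyond the scatter), where the departing group entered and the number rose beyond the scatter. A partial reversal of similar size, towards a lower number in this assay, is therefore expected. The expected change is an at least 2.8-fold lower number from compound 2 to compound 3 (0.45 log units; beyond the scatter). Compound 3 is expected at 35000 nM, with an estimated range of 12000 nM to 100000 nM.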

Compound 3, half-maximal inhibitory concentration: 13800 nM
Compound 3: the middle estimate sits 2.5-fold (0.40 log units) above what was measured; low and high end bracket the measured number.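

In this assay the place on a saturated chain carbon, three bonds along the chain from an oxygen on an aromatic ring, accepts 4-methylpiperazin-1-yl as well as piperidin-1-yl, with a 1.5-fold lower number from compound 1 to compound 3 (0.18 log units; within the scatter) as the step between them. The change away from 1,2,3,4-tetrahydroisoquinolin-2-yl gives an at least 7.2-fold lower number from compound 2 to compound 3 (0.86 log units; beyond the scatter) and so recovers the earlier loss. The reading of compound 2 is a limit and not a number: the limit of > 100000 nM in this assay, at which 1 of the 3 values shown sits.

On these data alone, whether this extends to morpholin-4-yl or dimethylamino at the chain end remains open. As far as these compounds go, the effect of a shorter chain also remains open.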